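The source may hold more compounds than are shown below. What is called first, only, known or untested is meant among the compounds shown, and "the series" means these compounds.

Values in a functional assay on cells (leukaemia cell line, Homo sapiens) for inhibition, read by sulforhodamine B assay, with a stated time of 48 h; on this read-out lower numbers stand for higher toxicity in this test and higher numbers for lower toxicity in this test:
Compound 1 `O=S(=O)(Nc1ccc(Cl)c(Cl)c1)c1ccc(-c2cnc(C3CC3)o2)cc1` gives > 100000 nM as a limit
Compound 2 `O=S(=O)(Nc1ccc(Cl)c(F)c1)c1ccc(-c2cnc(C3CC3)o2)cc1` gives > 100000 nM as a limit
Compound 3 `O=S(=O)(Nc1cc(F)cc(F)c1)c1ccc(-c2cnc(C3CC3)o2)cc1` gives > 100000 nM as a limit

Among the measured compounds shown here, no compound in this set has yet given a number, and the record holds only the limit of > 100000 nM in this assay, at which 3 of the 3 values shown sit, as its common result. Compound 3 stands at > 100000 nM in this assay, and this is a limit, not a number.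

Compound 4 `Cc1cc(F)cc(NS(=O)(=O)c2ccc(-c3cnc(C4CC4)o3)cc2)c1` keeps the rest of compound 3 and turns 3,5-difluorophenyl into 3-fluoro-5-methylphenyl, with methyl in place of fluoro on an aromatic carbon.

Three measured steps change the same phenyl group: a step that the two limits leave unreadable from compound 1 to compound 2, a step that the two limits leave unreadable from compound 1 to compound 3 and a step that the two limits leave unreadable from compound 2 to compound 3. None has a readable size, and none brings in methyl. For the measured compounds named here, with the limit of > 100000 nM in this assay, at which 3 of the 3 values shown sit, as the only guide, no step beyond the scatter is expected in either direction, and another limit is the likeliest report. The expected step is a number no higher from compound 3 to compound 4 (the limit leaves the size open) as an estimate. For compound 4 the estimated value is 100000 nM, with an expected range from 50000 nM to 200000 nM.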

Compound 4, concentration lethal to 50% of the cells: 78100 nM
Compound 4: the middle estimate sits 1.3-fold (0.11 log units) above what was measured, and the stated range covers the measured number.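

In this assay, among the compounds shown here, compound 4 gives the first number of the set, so a change on this phenyl group now registers as a measured value, while the rest of the set stays at one shared limit: the limit of > 100000 nM in this assay, at which 3 of the 4 values shown sit. Methyl in place of fluoro gives an at least 1.2-fold lower number from compound 3 to compound 4 (0.10 log units; that floor lies within the scatter), and the 3-fluoro-5-methylphenyl group set against the two chlorinated phenyl groups gives an at least 1.2-fold lower number from compound 2 to compound 4 (0.10 log units; that floor lies within the scatter) and an at least 1.2-fold lower number from compound 1 to compound 4 (0.10 log units; that floor lies within the scatter). All three are floors only, and the steps among compound 1, compound 2 and compound 3 cannot be read.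

Going by these compounds, the true size of each step stays open as long as those three compounds hold only a limit. Also open, on these data alone, is whether an ethyl group, a methoxy group or an amine in this same place would give a lower number than methyl does.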